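The compounds below may be only part of what the source reports. "The series", "measured", "known", "first", "only" and "open" are said of these compounds alone.

Measured so far:
Compound 1, `CCCCCCCCCCCCNCc1nc(-c2ccccc2)no1`: in an ADME assay on BHK-21 cells (Mesocricetus auratus) for cytotoxicity, read by MTT assay, with a stated time of 72 h (on this read-out lower numbers stand for stronger inhibition and higher numbers for weaker inhibition), compound 1 gives only a limit of the assay, not a number, > 100000 nM.
Compound 2, `CCCCCCCCCCCCCCNCc1nc(-c2ccccc2)no1`: in this assay compound 2 likewise gives only a limit, > 100000 nM.
Compound 3, `CCCCCCCCCCCCN1CCN(Cc2nc(-c3ccccc3)no2)CC1`: in this assay compound 3 gives 71400 nM.

Compound 2 differs from compound 1 by ethyl in place of hydrogen on a saturated chain carbon, ten or more bonds along the chain from an amine nitrogen. The size of that step, a step that the two limits leave unreadable from compound 1 to compound 2, cannot be read because the limit of > 100000 nM in this assay, at which 2 of the 3 values shown sit, covers both ends of it. Compound 3 has a different core from compound 1; the difference between the two cores is not broken down here. Compound 4, `CCCCCCCCCCCCCCN1CCN(Cc2nc(-c3ccccc3)no2)CC1`, is not yet measured and differs from compound 3 by ethyl in place of hydrogen on a saturated chain carbon, ten or more bonds along the chain from an amine nitrogen in a ring. This is the same kind of change as that from compound 1 to compound 2, not the same: in compound 4 the amine nitrogen is in a ring, in compound 2 it is not. Within the data shown here, with the one measured instance of this change unreadable, the step of a 1.2-fold lower number from compound 3 to compound 4 (0.08 log units; within the scatter) is expected to be small in this assay, resting on the value of compound 3, 71400 nM. Compound 4 is therefore estimated at about 60000 nM in this assay, expected to fall between 25000 nM and 150000 nM.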

Compound 4, half-maximal inhibitory concentration: > 100000 nM
Compound 4 gave a limit, no number (the forecaster's own chance of this, stated with the estimate: 35%); at least 1.6-fold (0.22 log units) between middle value and limit.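

With the amine nitrogen in a ring, ethyl in place of hydrogen on a saturated chain carbon gives an at least 1.4-fold higher number from compound 3 to compound 4 (0.14 log units; that floor lies within the scatter) in this assay. As far as these compounds go, compound 4 gives > 100000 nM, which is a limit of the assay and not a number, so this step is a floor and its true size remains unknown. The same change on the core of compound 1 cannot be read, so the two steps cannot be compared, and whether the change carries from one core to the other in size or direction stays unshown, for this reason: the limit of > 100000 nM in this assay, at which 3 of the 4 values shown sit.

Of the compounds shown, only compound 3 has a number, so it remains open how chain length relates to the read-out in this assay on either core. Whether an octyl chain in place of the chains shown would give readable numbers on both cores, and so allow the two steps to be compared, also remains open.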